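The source may hold more compounds than are shown below. What is called first, only, known or untested is meant among the compounds shown, and "the series" means these compounds.

Working notes on the series. The shared core of compound 1 `O=C(CSc1nnc(-c2ccncc2)o1)N/N=C/c1ccccc1` carries a phenyl on a carbon with a double bond to nitrogen. In a functional assay on HepG2 cells (Homo sapiens) for cytotoxicity, read by MTT assay, with a stated time of 48 h (a higher number here means a weaker inhibitor, a lower number a stronger inhibitor), compound 1 gives 17300 nM, the highest of the two numbers recorded so far. Compound 2 `O=C(CSc1nnc(-c2ccncc2)o1)N/N=C/c1cc(Br)ccc1O` gives 6490 nM in this assay, and the step of a 2.7-fold lower number from compound 1 to compound 2 (0.43 log units; beyond the scatter) shows that a halogen-bearing aryl at this position can lower the number. Compound 3 `O=C(CSc1nnc(-c2ccncc2)o1)N/N=C/c1ccc(Cl)cc1Cl` differs from compound 1 by 2,4-dichlorophenyl in place of phenyl on a carbon with a double bond to nitrogen. Among the compounds with values here, the only measured step that bears on this change is a 2.7-fold lower number from compound 1 to compound 2 (0.43 log units; beyond the scatter), but it also introduced a hydroxy group, so its transfer to compound 3 is uncertain. A modest lowering in this assay is expected for compound 3, roughly a 1.9-fold lower number from compound 1 to compound 3 (0.28 log units; within the scatter), since compound 2 moved by a 2.7-fold lower number from compound 1 to compound 2 (0.43 log units; beyond the scatter). Compound 3 is therefore estimated at 9000 nM, with a range of 4000 nM to 20000 nM.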

Compound 3, half-maximal inhibitory concentration: 18600 nM
For compound 3 the middle estimate is 2.1-fold (0.32 log units) below the measured one; the range from low to high includes it.
By their numbers in this assay, from the lowest: compound 2; then compounds 1 and 3 (each within the scatter of the next).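

In this assay, 2,4-dichlorophenyl in place of phenyl on a carbon with a double bond to nitrogen gives a 1.1-fold higher number from compound 1 to compound 3 (0.03 log units; within the scatter), so halogen on this aryl does not by itself set a compound apart from phenyl. The step of a 2.9-fold higher number from compound 2 to compound 3 (0.46 log units; beyond the scatter) separates 2,4-dichlorophenyl from 5-bromo-2-hydroxyphenyl, which leaves compound 2 with the lowest number of the three and makes compound 3 the compound that goes against the reading of halogen as enough to lower the number. No available evidence accounts for this difference.

The compounds shown leave open whether the bromine, the hydroxy group or the two together go with the lower number of compound 2. Going by these compounds, how an amine or a carboxylic acid on this aryl would read in this assay also remains open.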